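A few compounds are considered here, and "the series" means these few. Any claim that something is new, unique, unknown or untested is made for them only; others in the source may bear on it.

Compound 1, `CCCCOc1nc(C(C)(C)C)ccc1CNC(=O)C(C)c1ccc(NS(C)(=O)=O)c(F)c1`, is the reference point here. For the measured compounds named here, in an assay on cells for antagonist activity at transient receptor potential cation channel subfamily V member 1 (Homo sapiens), read by FLIPR and calcium flux, with a stated time of 6 min (on this read-out lower numbers stand for stronger inhibition and higher numbers for weaker inhibition), compound 1 gives 0.9 nM, which is the lowest of the two numbers so far. Going by the values given here, its only neighbour is compound 2, `CC(C(=O)NCc1ccc(C(C)(C)C)nc1OCc1ccccc1)c1ccc(NS(C)(=O)=O)c(F)c1`, which in this assay gives 4.4 nM; the step is a 4.9-fold higher number from compound 1 to compound 2 (0.69 log units; beyond the scatter), and it arises from a phenyl in place of propyl on a saturated chain carbon bound to an oxygen on an aromatic ring.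

Compound 3, `CCCCSc1nc(C(C)(C)C)ccc1CNC(=O)C(C)c1ccc(NS(C)(=O)=O)c(F)c1`, differs from compound 1 in a different way: butylsulfanyl in place of butoxy on an aromatic carbon. Among the compounds with values here, no measured step alters the atom that links the butyl chain to the aromatic carbon, so the one step on record, a 4.9-fold higher number from compound 1 to compound 2 (0.69 log units; beyond the scatter), bears on it only loosely, as evidence that this corner of the shared core tolerates change with a modest penalty. A step of similar or smaller size is therefore expected, most likely toward a higher number, and possibly none beyond the scatter. Compound 3 is accordingly estimated at 1.8 nM in this assay, within a range of 0.5 nM to 6 nM, a step of a 2.0-fold higher number from compound 1 to compound 3 (0.30 log units; within the scatter).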

Compound 3, inhibition constant: 3.2 nM
The estimate for compound 3 lay 1.8-fold (0.25 log units) below the measured number; the range from low to high includes it.
By their numbers in this assay, from the lowest: compound 1; then compounds 3 and 2 (each within the scatter of the next).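

In this assay, for the compounds shown here, this is the first measured change to the atom that links the butyl chain to the aromatic carbon, and with the chain kept, butylsulfanyl in place of butoxy is not a silent swap: the result is a 3.6-fold higher number from compound 1 to compound 3 (0.55 log units; beyond the scatter). Compared with the benzyloxy group, the butylsulfanyl group gives a 1.4-fold lower number from compound 2 to compound 3 (0.14 log units; within the scatter), so these two groups cannot be told apart on this read-out, while butoxy in compound 1 keeps the lowest number of the three, with both of its steps beyond the scatter. Nothing available explains why sulfur in place of oxygen at this link gives this step.

The compounds shown leave open how far the link itself matters, which a butylamino group or a plain pentyl chain on the same aromatic carbon would test further, and how far the chain length matters, which a shorter ethoxy or a longer hexyloxy group would test with the oxygen kept. They also leave open whether the step from butoxy to butylsulfanyl would stay the same with a trifluoromethyl group in place of the tert-butyl group.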